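Three aryl-substituted analogues and a methylamino replacement

The compounds below may be only part of what the source reports. "The series", "measured", "known", "first", "only" and "open" are said of these compounds alone.

Measured in an assay on isolated protein for inhibition of activin receptor type-2A (Homo sapiens), read by 33P incorporation, with a stated time of 20 min, in the presence of a further agent that is not named here; a higher number here means a weaker inhibitor, a lower number a stronger inhibitor:
Compound 1, `COc1cc(-c2cnn3cc(OC)c(-c4cc(C)no4)nc23)ccn1`, gives 3000 nM.
Compound 2, `COc1cc(-c2cnn3cc(OC)c(C(C)C)nc23)ccn1`, gives 3800 nM.
Compound 3, `COc1cc(-c2cnn3cc(OC)c(C(C)(C)O)nc23)ccn1`, gives 2700 nM.

Compound 3 has the lowest of the three numbers, but only narrowly: the step of a 1.1-fold lower number from compound 1 to compound 3 (0.05 log units; within the scatter) and the step of a 1.4-fold lower number from compound 2 to compound 3 (0.15 log units; within the scatter) both fall within the scatter, as does a 1.3-fold higher number from compound 1 to compound 2 (0.10 log units; within the scatter). On these numbers the three compounds cannot be ordered.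

Compound 4, `CNc1nc2c(-c3ccnc(OC)c3)cnn2cc1OC`, differs from compound 3 at one place: methylamino in place of 1-hydroxy-1-methylethyl on an aromatic carbon. All three measured steps change the group on this same aromatic carbon, and none of them moved the number beyond the scatter, whether a ring, an isopropyl or a 1-hydroxy-1-methylethyl sat there. The replacement by methylamino has no direct precedent among these compounds, so the expectation rests on the apparent tolerance of this position. Compound 4 is therefore expected to show a step of a 1.1-fold higher number from compound 3 to compound 4 (0.05 log units; within the scatter), that is, no change beyond the scatter. The estimate for compound 4 in this assay is 3000 nM, with a range from 1400 nM to 6500 nM.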

Compound 4, half-maximal inhibitory concentration: 310 nM
The estimate for compound 4 lay 9.7-fold (0.99 log units) above the measured number; measured number below the stated range.
By their numbers in this assay, from the lowest: compound 4; then compounds 3, 1 and 2 (each within the scatter of the next).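

The earlier compounds shown here suggested that this aromatic carbon, next to the ring nitrogen and ortho to a methoxy group, accepted any group with little consequence, but that holds only among the three groups first seen there. In this assay, within the data shown here, replacing 1-hydroxy-1-methylethyl gives an 8.7-fold lower number from compound 3 to compound 4 (0.94 log units; beyond the scatter) while replacing isopropyl gives a 12-fold lower number from compound 2 to compound 4 (1.09 log units; beyond the scatter) and replacing 3-methyl-1,2-oxazol-5-yl gives a 9.7-fold lower number from compound 1 to compound 4 (0.99 log units; beyond the scatter) so methylamino stands apart from all three, and it is also the only one of the four groups joined to this carbon through nitrogen. Since methylamino and 1-hydroxy-1-methylethyl have the same counts of hydrogen-bond donors and acceptors but differ in heavy atoms, those counts do not separate this pair, and nothing measured here accounts for the gain.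

The compounds shown leave open whether the gain depends on the nitrogen link, on the hydrogen it carries or on the methyl group. A primary amine, dimethylamino or ethylamino on this same carbon, with the rest of the core unchanged, would bear on that question, and a methoxy group there would test whether a different linking atom could serve.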